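The source may report more compounds than this note shows. Statements on the series, on what has been measured and on what is new or still open speak of the compounds shown alone.

In a functional assay on brain (Rattus norvegicus, strain Wistar) for inhibition (a lower number here means a stronger inhibitor, a higher number a weaker inhibitor), compound 1 (`CCCc1ccc(-c2c(C)[nH]c(=O)n2C)cc1`) gives 21500 nM and compound 2 (`Cc1[nH]c(=O)n(C)c1-c1ccc(OC(C)C)cc1`) gives 20400 nM. For the measured compounds named here, these are the only two numbers, and they lie within the scatter of each other, so compound 2 stands level with compound 1. Compound 3 (`Cc1[nH]c(=O)n(C)c1-c1ccc(CC(C)C)cc1`) carries isobutyl in place of isopropoxy on an aromatic carbon. Going by the values given here, one measured step bears on this change: a 1.1-fold lower number from compound 1 to compound 2 (0.02 log units; within the scatter), where isopropoxy took the place of propyl on an aromatic carbon. That single step gives no sign that exchanging these chains moves the number, so no shift beyond the scatter is expected in this assay, and no direction can be favoured. The expected step is a 1.0-fold lower number from compound 2 to compound 3 (0.01 log units; within the scatter). For compound 3 the estimated value is 20000 nM, with an expected range of 9000 nM to 45000 nM.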

Compound 3, half-maximal inhibitory concentration: 7800 nM
Estimate against measurement, compound 3: 2.6-fold (0.41 log units) above; the whole stated range lies above it.
By their numbers in this assay, from the lowest: compound 3; then compounds 2 and 1 (each within the scatter of the next).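

The chain on this aromatic carbon can move the number after all: in this assay, isobutyl in place of isopropoxy gives a 2.6-fold lower number from compound 2 to compound 3 (0.42 log units; beyond the scatter). The propyl comparison points the same way, with methyl in place of hydrogen on a saturated chain carbon giving a 2.8-fold lower number from compound 1 to compound 3 (0.44 log units; beyond the scatter), so isobutyl gives a lower number than either of the two chains that stood level, though both steps are modest. No measured evidence accounts for these steps.

As far as these compounds go, whether the number falls further with a longer chain such as pentyl, or with cyclohexyl or tert-butyl on this carbon, remains open. Also open, from the compounds shown here alone, is how an amine or a carboxylic acid at this place would compare with isobutyl.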